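The source may hold more compounds than are shown below. What is called first, only, known or untested is meant among the compounds shown, and "the series" means these compounds.

Measured in a functional assay on MCF7 cells (Homo sapiens) for inhibition, read by CCK-8 assay, with a stated time of 48 h; on this read-out higher numbers stand for weaker inhibition of growth and lower numbers for stronger inhibition of growth:

Compound 1 `Cc1ccccc1Nc1nc(NCc2ccccc2)ncc1Cl` gives > 100000 nM
Compound 2 `CCN1CCN(c2ccc(Nc3ncc(Cl)c(Nc4ccccc4C)n3)cc2)CC1` gives 3160 nM
Compound 3 `CN1CCN(c2ccc(Nc3ncc(Cl)c(NCc4ccc(C(F)(F)F)cc4)n3)nc2)CC1` gives 28400 nM

The entry for compound 1 is a limit of the assay and not a number. Of the two true numbers, compound 3 holds the higher and compound 2 the lower, and the gap between them lies beyond the scatter.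

Compound 4 `CN1CCN(c2ccc(Nc3ncc(Cl)c(NCc4ccco4)n3)nc2)CC1` carries furan-2-yl in place of 4-(trifluoromethyl)phenyl on a saturated chain carbon bound to a nitrogen on an aromatic ring. Within the data shown here, no measured pair shows this exchange, so the step expected in this assay is none beyond the scatter (a 1.1-fold higher number from compound 3 to compound 4 (0.02 log units; within the scatter)). Compound 4 is estimated at 30000 nM (expected range 9000 nM to 100000 nM).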

Compound 4, concentration for 50% growth inhibition: 21300 nM
Estimate against measurement, compound 4: 1.4-fold (0.15 log units) above; the range from low to high includes it.
By their numbers in this assay, from the lowest: compound 2; then compounds 4 and 3 (each within the scatter of the next). At a limit, above all of these: compound 1.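

At the saturated chain carbon bound to a nitrogen on an aromatic ring, furan-2-yl in place of 4-(trifluoromethyl)phenyl gives, in this assay, a 1.3-fold lower number from compound 3 to compound 4 (0.12 log units; within the scatter). Exchanging the six-membered carbon ring and its trifluoromethyl for a five-membered ring with one oxygen therefore leaves the read-out within the scatter at this place. Both compounds give true numbers, and neither is a limit of the assay: the limit of > 100000 nM in this assay, at which 1 of the 4 values shown sits.

From the compounds shown here alone, whether a morpholine, a primary amine or a carboxylic acid on this chain carbon would shift the number beyond the scatter stays open. So does the effect of a longer chain between the ring and the nitrogen.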